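A few compounds are considered here, and "the series" means these few. Any claim that something is new, unique, unknown or untested is made for them only; others in the source may bear on it.

The measured compounds:

Compound 1, `c1ccc2c(c1)CCC2NC1CCN(CCCc2c[nH]c3ccc(-n4cnnc4)cc23)CC1`, gives 280 nM in an assay on CHO cells for displacement of a labelled ligand from 5-hydroxytryptamine receptor 1B (Homo sapiens); on this read-out higher numbers stand for weaker inhibition and lower numbers for stronger inhibition.
Compound 2, `CC(=O)Nc1ccc(CNC2CCN(CCCc3c[nH]c4ccc(-n5cnnc5)cc34)CC2)cc1`, gives 45 nM in this assay.
Compound 3, `c1ccc2c(c1)CCC2NCC1CCN(CCCc2c[nH]c3ccc(-n4cnnc4)cc23)CC1`, gives 25 nM in this assay.

Two changes separate these three. Between compound 1 and compound 2 the change is 4-acetamidobenzyl in place of 2,3-dihydro-1H-inden-1-yl on an amine nitrogen, and it brings a 6.2-fold lower number from compound 1 to compound 2 (0.79 log units; beyond the scatter). Between compound 1 and compound 3 the cores differ by ((2,3-dihydro-1H-inden-1-yl)amino)methyl in place of (2,3-dihydro-1H-inden-1-yl)amino on a saturated ring carbon, and that brings an 11-fold lower number from compound 1 to compound 3 (1.05 log units; beyond the scatter). The values of compound 2 and compound 3 lie within the usual scatter of each other, so nothing can be said about which is the stronger of the two.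

Compound 4, `CC(=O)Nc1ccc(CNCC2CCN(CCCc3c[nH]c4ccc(-n5cnnc5)cc34)CC2)cc1`, has not yet been measured in this assay. It carries the core of compound 3 together with the group of compound 2: from compound 3 to compound 4 the change is 4-acetamidobenzyl in place of 2,3-dihydro-1H-inden-1-yl on an amine nitrogen. This is the same kind of change as from compound 1 to compound 2, but not the same: in compound 1 the amine nitrogen has a saturated ring carbon as its other neighbour, in compound 3 a saturated chain carbon.

For the measured compounds named here, the expectation for compound 4 is a step of a 4.2-fold lower number from compound 3 to compound 4 (0.62 log units; beyond the scatter) in this assay, resting on the step of a 6.2-fold lower number from compound 1 to compound 2 (0.79 log units; beyond the scatter), with some allowance taken: the surroundings of the amine nitrogen are not identical, and only one earlier example of this change exists. Compound 4 is therefore estimated at 6 nM in this assay, most likely between 2 nM and 20 nM.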

Compound 4, half-maximal inhibitory concentration: 8.9 nM
Estimate against measurement, compound 4: 1.5-fold (0.17 log units) below; the measured number falls inside the stated range.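

In this assay, putting 4-acetamidobenzyl in place of 2,3-dihydro-1H-inden-1-yl on the amine nitrogen again lowers the number, giving a 2.8-fold lower number from compound 3 to compound 4 (0.45 log units; beyond the scatter), so the change points the same way on the core of compound 1 and on the core of compound 3. Set side by side, the two steps cannot be told apart in size, and the gap that appears in their printed values is no sign that the core alters what the change does: the same change on two cores in this assay, a 6.2-fold lower number (0.79 log units; beyond the scatter) from compound 1 to compound 2 and a 2.8-fold lower number (0.45 log units; beyond the scatter) from compound 3 to compound 4, 2.2-fold (0.35 log units) apart, within the scatter of two such steps This shows that the change carried over in direction from one core to the other, but it rests on just two pairs of compounds, so it does not show that the change would hold on further cores in this series, nor does it explain why the number falls.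

On these data alone, what a plain benzyl group, or a benzyl group carrying an amine or a carboxylic acid instead of the acetamido group, would do remains open, so the step cannot yet be assigned to one part of 4-acetamidobenzyl. Also open, as far as these compounds go, is how the numbers would move if a longer chain linked the amine nitrogen to the saturated ring of the core.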